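Adding one hydroxy group to compound 1

The source may report more compounds than this note shows. Statements on the series, on what has been measured and on what is new or still open speak of the compounds shown alone.

In a functional assay on SK-N-SH cells (Homo sapiens) for inhibition, read by MTT assay, with a stated time of 72 h, tested at 50 uM (a lower number here means less inhibition of growth, a higher number more inhibition of growth at the concentration tested), compound 1 (`C=CCc1cc(O)c(O)c(CN2CCC(C)CC2)c1`) reaches 84.2% of growth inhibition, level within the scatter with compound 3 (`C=CCc1ccc(OCc2cn(-c3ccccc3CO)nn2)c(O)c1`) at 87.1% of inhibition. Compound 2 (`C=CCc1ccc(OCc2cn(-c3ccc(C#N)cc3)nn2)c(O)c1`) gives 62.5% of inhibition. Its number lies lower than that of compound 1, and this gap exceeds the scatter. Compound 4 (`C=CCc1cc(O)c(O)c(CN2CCC(CO)CC2)c1`) carries one change (hydroxy in place of hydrogen on a saturated chain carbon bound to a saturated ring carbon), methyl to hydroxymethyl. Among the compounds with values here, the only measured step that brings in a hydroxymethyl group is a number 24.6 percentage points higher from compound 2 to compound 3 (beyond the scatter) and it is modest, but it exchanges a whole different group in another pair of compounds, so it is only a loose guide. No step beyond the scatter is therefore expected in this assay for this change. The estimated shift is a number 4.2 percentage points lower from compound 1 to compound 4 (within the scatter) and stays within the scatter. Compound 4 is expected at 80% within a range of 64% to 93% in this estimate.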

Compound 4, percent growth inhibition at one concentration: 49.4%
Beside the measured number, compound 4's estimate is 30.6 percentage points above it; measured number outside the range, below it.
By their numbers in this assay, from the lowest: compound 4; then compound 2; then compounds 1 and 3 (each within the scatter of the next).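

The step of a number 34.8 percentage points lower from compound 1 to compound 4 (beyond the scatter) shows that in this assay this position responds strongly to a small change: one added hydroxy, on a saturated chain carbon bound to a saturated ring carbon, moves the number beyond the scatter. The earlier step to a hydroxymethyl group went upward, so across these compounds that group has no fixed direction. Nothing shown here explains the drop.

From the compounds shown here alone, whether an amine or a carboxylic acid at this carbon would lower the number as well remains open. So does whether a longer chain ending in hydroxy would.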